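The source may report more compounds than this note shows. Statements on the series, on what has been measured and on what is new or still open speak of the compounds shown alone.

Measured in a functional assay on HeLa cells (Homo sapiens) for inhibition, read by MTT assay, with a stated time of 72 h; a lower number here means a stronger inhibitor, a higher number a weaker inhibitor:
- Compound 1 `Nc1ncnc2c1c(-c1cnc3[nH]ccc3c1)nn2CC(=O)NO`: "not determined" (no result reported)
- Compound 2 `Nc1nc2cc(-c3nn(CCCC(=O)NO)c4ncnc(N)c34)ccc2o1`: > 150000 nM

Going by these compounds, compound 1 has no single number to stand on, so its place stays open. Going by the values given here, the only other reading is the limit of > 150000 nM in this assay, at which 1 of the 2 values shown sits. It belongs to compound 2 and is a limit, not a number.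

Compound 3 `Nc1ncnc2c1c(-c1cnc3[nH]ccc3c1)nn2CCCCC(=O)NO` is the next entry and keeps the core of compound 1. The change is 3-(hydroxycarbamoyl)propyl in place of hydroxycarbamoyl on a saturated chain carbon bound to an aromatic nitrogen.

Among the compounds with values here, no measured step supports a size for this change. A sizeable move towards stronger inhibition in this assay, beyond the scatter, is nevertheless expected, with low confidence. Compound 3 is estimated at 20000 nM, with an expected range of 1500 nM to 150000 nM.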

Compound 3, half-maximal inhibitory concentration: > 150000 nM
Compound 3: only a limit was reported; the forecaster's own chance of this, stated with the estimate: 30%; middle value at least 7.5-fold (0.87 log units) away from the limit.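

In this assay compound 3 gives > 150000 nM, a limit and not a number. Compound 1 has no result, so no step can be read between compound 1 and compound 3. The compounds shown leave open whether 4-(hydroxycarbamoyl)butyl in place of (hydroxycarbamoyl)methyl changes inhibition at all, and all that stands is a single limit: the limit of > 150000 nM in this assay, at which 2 of the 3 values shown sit.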